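Swapping a dimethylamino for an amino on a fused core

The compounds below may be only part of what the source reports. "The series", "measured", "known", "first", "only" and "open" are said of these compounds alone.

Compound 2 `CN(C)c1[nH]ccc2ncnc1-2` carries a dimethylamino group on its fused core, and in a functional assay on EL4 cells (Mus musculus) for inhibition, tested at 100 uM (a higher number here means more inhibition at the concentration tested (going by the name of the read-out), a lower number less inhibition), compound 2 gives 25%. Among the numbers shown this is the higher of two. Compound 1 `CN(C)c1nccc2c1ncn2C1O[C@H](CO)[C@@H](O)[C@H]1O`, which bears a sugar ring instead of a ring hydrogen, gives 10% in this assay, a gap from compound 2 that lies beyond the usual scatter. Compound 3 `[N-]=[N+]=Nc1nccc2ncn([C@H]3C[C@H](O)[C@@H](CO)O3)c12` gives < 5%, which is a limit of this assay and not a number. That value stands at the limit of < 5% in this assay, at which 1 of the 3 values shown sits.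

Compound 4 `Nc1[nH]ccc2ncnc1-2` has not yet been measured. It differs from compound 2 in one place: amino in place of dimethylamino on an aromatic carbon. For the measured compounds named here, no measured pair in this set differs in a single spot, so there is no direct guide to the size of this change. The step of a number 7 percentage points lower from compound 2 to compound 4 (within the scatter) is expected to be small, within the scatter or a modest drop. Compound 4 is therefore estimated to give 18% in this assay, in a range from 5% to 35%, with a real chance that only a limit is reported.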

Compound 4, a percentage reported as inhibition, at one concentration (the size of the read-out at that concentration, not a potency): < 5%
Compound 4 gave a limit, no number (the forecaster's own chance of this, stated with the estimate: 25%); middle value at least 13 percentage points away from the limit.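

Swapping dimethylamino for amino on this aromatic carbon is the first single-place change in the set, and in this assay it brings a number at least 20 percentage points lower from compound 2 to compound 4 (beyond the scatter). The group on the aromatic carbon next to the ring nitrogen therefore matters for this read-out, and the inhibition seen with dimethylamino does not survive when only amino remains. Compound 4 gives < 5%, which is a limit of the assay and not a number, so the full size of the step stays unknown, and such limits now make up a larger part of the set: the limit of < 5% in this assay, at which 2 of the 4 values shown sit.

The compounds shown leave open how a methylamino group or a diethylamino group would behave at this position. They also leave open whether the same swap would matter on the sugar-bearing core of compound 1.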